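The source may hold more compounds than are shown below. What is called first, only, known or untested is meant among the compounds shown, and "the series" means these compounds.

Three compounds have numbers in a functional assay on DLD-1 cells (Homo sapiens); a lower number here means a stronger inhibitor, a higher number a weaker inhibitor. Compound 1, `CC(C)C/N=C(\S)N1CCN(c2ccc(N(Cc3c[nH]cn3)S(=O)(=O)c3ccccc3)cc2)CC1`, gives 800 nM. Compound 2, `O=S(=O)(c1ccccc1)N(Cc1c[nH]cn1)c1ccc(N2CCN(C(=S)NC3CCCCC3)CC2)cc1`, gives 1000 nM; the step of a 1.3-fold higher number from compound 1 to compound 2 (0.10 log units; within the scatter) concerns a group on the amine nitrogen of the shared core. Compound 3, `N#Cc1ccc(Cn2cncc2CN(C(=O)c2ccccc2F)c2ccc(N3CCN(C(=O)c4ccc(Cl)s4)CC3)cc2)cc1`, gives 20 nM, the lowest of the three numbers, with the nearest being compound 1 and the furthest compound 2, both far beyond the scatter.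

Compound 4, `COc1ccc(C(=O)N(Cc2cncn2Cc2ccc(C#N)cc2)c2ccc(N3CCN(C(=O)c4ccc(Cl)s4)CC3)cc2)cc1`, has not been measured. It differs from compound 3 as follows: 4-methoxyphenyl in place of 2-fluorophenyl on a carbonyl carbon. No measured step touches this position; the only step shown, from compound 1 to compound 2, sits elsewhere and stays within the scatter, so it gives no direction for this change. The expectation is therefore a step of no clear direction and modest size, a 1.5-fold higher number from compound 3 to compound 4 (0.18 log units; within the scatter), with a wide range. Compound 4 is estimated at 30 nM in this assay, expected between 8 nM and 120 nM.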

Compound 4, half-maximal inhibitory concentration: 80 nM
Compound 4: middle estimate off by 2.7-fold (0.43 log units), on the low side; low and high end bracket the measured number.
By their numbers in this assay, from the lowest: compound 3; then compound 4; then compounds 1 and 2 (each within the scatter of the next).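

In this assay the group on this carbonyl carbon, whose other neighbour is the amide-type nitrogen, proves to matter: 4-methoxyphenyl in place of 2-fluorophenyl gives a 4.0-fold higher number from compound 3 to compound 4 (0.60 log units; beyond the scatter) and this lies beyond the scatter. The only earlier step between compounds differing in one place stayed within the scatter and concerned another position, so this is the first sign among the compounds shown that a single exchange can move the number. Nothing at hand bears on why the number rises here.

The compounds shown leave open whether the step goes with the loss of the fluorine or the arrival of the methoxy group, which a plain phenyl on this carbonyl carbon would help to separate. Going by these compounds, how a non-aromatic group such as cyclohexyl, or a pyridine ring, would fare at this place also remains open.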